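Fused ring out, fluoropyrazole in: expected loss

A few compounds are considered here, and "the series" means these few. Any claim that something is new, unique, unknown or untested is made for them only; others in the source may bear on it.

Compound 3 `CCCC(Oc1ccc(-n2cc3c(n2)CCCC3)cc1)c1ccc(C(=O)NCCC(=O)O)cc1` gives 4200 nM in a functional assay on cells for antagonist activity at Glucagon receptor (Homo sapiens), read by cAMP accumulation, in the presence of a further agent that is not named here (on this read-out lower numbers stand for stronger inhibition and higher numbers for weaker inhibition), the highest of the two numbers in hand; compound 2 `CCCC(Oc1ccc(-n2cc3ccccc3n2)cc1)c1ccc(C(=O)NCCC(=O)O)cc1` gives 2000 nM, and the step of a 2.1-fold higher number from compound 2 to compound 3 (0.32 log units; beyond the scatter) is modest. Compound 1 `CCCC(Oc1ccc(-n2cc(OC)cn2)cc1)c1ccc(C(=O)NCCC(=O)O)cc1` reports only a limit in this assay, > 23000 nM. Compound 4 `CCCC(Oc1ccc(-n2cc(F)cn2)cc1)c1ccc(C(=O)NCCC(=O)O)cc1` carries a group of 6 heavy atoms (3 carbon, 2 nitrogen, 1 fluorine; one five-membered aromatic ring with 2 hetero atoms) in place of a group of 9 heavy atoms (7 carbon, 2 nitrogen; one five-membered aromatic ring with 2 hetero atoms, one six-membered non-aromatic ring of carbon only), on an aromatic carbon, which broadly reverses the change that separates compound 1 from compound 3. Within the data shown here, the step that bears on it is an at least 5.4-fold lower number from compound 1 to compound 3 (0.73 log units; beyond the scatter); fluorine in place of methoxy on the pyrazole has no measured counterpart here. The number for compound 4 is therefore expected to rise markedly, a 4.8-fold higher number from compound 3 to compound 4 (0.68 log units; beyond the scatter). Because compound 1 sits at the limit of > 23000 nM in this assay, at which 1 of the 3 values shown sits, a limit remains possible for compound 4 as well. Compound 4 is estimated at 20000 nM, within 6000 nM to 70000 nM.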

Compound 4, antagonist equilibrium constant: 10000 nM
The estimate for compound 4 lay 2.0-fold (0.30 log units) above the measured number, within the range that was stated.
By their numbers in this assay, from the lowest: compound 2; then compound 3; then compound 4. At a limit, above all of these: compound 1.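

Para to a large group, 4-fluoro-1H-pyrazol-1-yl gives a measured number rather than a limit, yet both groups with a second ring keep lower numbers: a 2.4-fold higher number from compound 3 to compound 4 (0.38 log units; beyond the scatter) and a 5.0-fold higher number from compound 2 to compound 4 (0.70 log units; beyond the scatter). Compound 1 stands at a limit, so the effect of fluoro in place of methoxy is only a bound: an at least 2.3-fold lower number from compound 1 to compound 4 (0.36 log units; beyond the scatter).

Where a pyrazole bearing chloro, methyl or nitrile at that ring carbon would fall relative to compound 4 remains open. So does whether a fused ring holding a further nitrogen would lower the number below that of compound 2.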